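Trimethoxyphenyl enone series: loss of one methoxy group

The source may report more compounds than this note shows. Statements on the series, on what has been measured and on what is new or still open speak of the compounds shown alone.

Measured so far in a functional assay on HCT-116 cells (Homo sapiens) for inhibition, read by sulforhodamine B assay, with a stated time of 72 h; on this read-out lower numbers stand for stronger inhibition and higher numbers for weaker inhibition:
compound 1 `COc1cc(OC)c(C(=O)/C=C/c2cn(-c3ccccc3)nc2-c2ccsc2)c(OC)c1`: 5200 nM
compound 2 `COc1cc(C(=O)/C=C/c2cn(-c3ccccc3)nc2-c2cccnc2)cc(OC)c1OC`: 8600 nM
compound 3 `COc1cc(OC)c(C(=O)/C=C/c2cn(-c3ccccc3)nc2-c2cccnc2)c(OC)c1`: 300 nM

Compound 3 stands lowest of the three numbers in this assay. Among the measured compounds shown here, its nearest neighbour is compound 1, the only measured step on the shared core, a 17-fold lower number from compound 1 to compound 3 (1.24 log units; beyond the scatter), which concerns the ring at the far end of the enone. Compound 2 carries the same pyridin-3-yl group as compound 3 but a different arrangement of the three methoxy groups; compound 2 gives 8600 nM, while compound 3 gives 300 nM. No listed step is computed for that pair.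

Compound 4 `COc1ccc(C(=O)/C=C/c2cn(-c3ccccc3)nc2-c2cccnc2)c(OC)c1` differs from compound 3 by hydrogen in place of methoxy on an aromatic carbon. For the measured compounds named here, no measured step bears on this change: the single measured step, a 17-fold lower number from compound 1 to compound 3 (1.24 log units; beyond the scatter), alters a different part of the molecule, and the comparison of compound 2 with compound 3 is not a one-point change. The expectation therefore rests only on the observation that both compounds with fewer or rearranged methoxy groups relative to compound 3 give higher numbers. For compound 4 the expected value in this assay is 1500 nM, with a range from 300 nM to 7000 nM. The expected step is a 5.0-fold higher number from compound 3 to compound 4 (0.70 log units; beyond the scatter), a move towards weaker inhibition, with wide uncertainty.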

Compound 4, half-maximal inhibitory concentration: 1300 nM
Compound 4: middle estimate off by 1.2-fold (0.06 log units), on the high side, within the range that was stated.
By their numbers in this assay, from the lowest: compound 3; then compound 4; then compounds 1 and 2 (each within the scatter of the next).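

In this assay, among the compounds shown here, the change from methoxy to hydrogen, on the aromatic carbon ortho to a large group and meta to two methoxy groups, gives a 4.3-fold higher number from compound 3 to compound 4 (0.64 log units; beyond the scatter) and is the first one-point reading on the methoxy groups themselves, whereas a 17-fold lower number from compound 1 to compound 3 (1.24 log units; beyond the scatter) concerned the ring at the far end of the enone. This methoxy therefore contributes measurably to the lower number of compound 3: with hydrogen in its place, inhibition is weaker beyond the scatter, although the step is only modest and compound 4 keeps a measurable value. No measurement at hand gives a reason for this step.

The compounds shown leave open whether another group on this carbon, such as ethoxy, hydroxyl or fluorine, would match compound 3 at 300 nM in this assay or give a higher number. Also open, as far as these compounds go, are whether the same change has a step of similar size with thiophen-3-yl in place of pyridin-3-yl, and what hydrogen does in place of either of the other two methoxy groups.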